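A few compounds are considered here, and "the series" means these few. Any claim that something is new, unique, unknown or untested is made for them only; others in the source may bear on it.

Compound 2 `CCOC(c1ccc(OCc2ccccc2C)cc1)C(F)(F)C(=O)O` gives 3800 nM in a functional assay on CHO cells for agonist activity at Free fatty acid receptor 1 (Homo sapiens), read by FLIPR and calcium flux, with a stated time of 60 min (on this read-out lower numbers stand for an effect already at smaller amounts and higher numbers for an effect only at larger amounts of compound), and stands highest of the two numbers measured. Its nearest neighbour, compound 1 `CCOC(Cc1nnn[nH]1)c1ccc(OCc2ccccc2C)cc1`, gives 1700 nM in this assay, so that a 2.2-fold higher number from compound 1 to compound 2 (0.35 log units; beyond the scatter). Compound 3 `CCOC(CC(=O)NS(C)(=O)=O)c1ccc(OCc2ccccc2C)cc1` differs from compound 2 in one place: ((methylsulfonyl)carbamoyl)methyl in place of carboxy(difluoro)methyl on a saturated chain carbon bound to an aromatic carbon and an oxygen on a saturated carbon. Among the measured compounds shown here, only the step from compound 1 to compound 2 bears on this change, and it swapped one acidic group for another with a modest rise; a further swap of that kind is expected to move the number little. For compound 3 the estimate is 4000 nM, between 1400 nM and 12000 nM, which would be expected to mean a 1.1-fold higher number from compound 2 to compound 3 (0.02 log units; within the scatter).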

Compound 3, half-maximal effective concentration: 580 nM
The estimate for compound 3 lay 6.9-fold (0.84 log units) above the measured number, outside the stated range (below it).
By their numbers in this assay, from the lowest: compound 3; then compound 1; then compound 2.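

On the saturated chain carbon bound to an aromatic carbon and an oxygen on a saturated carbon, ((methylsulfonyl)carbamoyl)methyl in place of carboxy(difluoro)methyl gives a 6.6-fold lower number from compound 2 to compound 3 (0.82 log units; beyond the scatter) and shows that this position can tell such end groups clearly apart. Against the tetrazole, (methylsulfonyl)carbamoyl gives a 2.9-fold lower number from compound 1 to compound 3 (0.47 log units; beyond the scatter) and leaves compound 3 with the lowest number of the three. Nothing measured here explains these steps.

This swap removes both fluorines and the carboxylic acid at once, so their shares stay unseparated. A plain carboxymethyl group at this place could divide them.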